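Cytotoxicity notes on a trifluoromethoxy-anilinopyrimidine series

A few compounds are considered here, and "the series" means these few. Any claim that something is new, unique, unknown or untested is made for them only; others in the source may bear on it.

Measured so far:
- compound 1, `FC(F)(F)Oc1ccc(Nc2cc(-c3ccc4[nH]ccc4c3)ncn2)cc1`: > 10000 nM
- compound 2, `CCn1cc2c(Nc3ccc(OC(F)(F)F)cc3)ncnc2n1`: > 10000 nM
- compound 3, `NS(=O)(=O)c1ccc(-c2cc(Nc3ccc(OC(F)(F)F)cc3)ncn2)cc1`: > 10000 nM

In an ADME assay on BaF3 cells (Mus musculus) for cytotoxicity (on this read-out lower numbers stand for an effect already at smaller amounts and higher numbers for an effect only at larger amounts of compound), compound 1 gives > 10000 nM, which is a limit of the assay and not a number. Compound 2 likewise sits at a limit, > 10000 nM. Compound 3 also reports a limit, > 10000 nM. Compound 1 thus stands nowhere in particular among the numbers shown: all three compounds share (the limit of > 10000 nM in this assay, at which 3 of the 3 values shown sit), so no step between measured compounds can be stated.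

Compound 4, `Nc1cccc(-c2cc(Nc3ccc(OC(F)(F)F)cc3)ncn2)c1`, differs from compound 1 by 3-aminophenyl in place of 1H-indol-5-yl on an aromatic carbon. With every measured value at the limit, the step that the limit leaves unreadable from compound 1 to compound 4 is expected to be none beyond the scatter. Compound 4 is expected at 15000 nM in this assay, with a range of 5000 nM to 50000 nM, most probably again only as a limit.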

Compound 4, half-maximal effective concentration: > 10000 nM
Compound 4 gave a limit, no number (the forecaster's own chance of this, stated with the estimate: 75%); the middle value is on the limit's open side.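

No step can be read from compound 1 to compound 4, because both values are limits and not numbers: the limit of > 10000 nM in this assay, at which 4 of the 4 values shown sit.

The compounds shown leave open at what concentration, if any, compound 1 or compound 4 would show an effect in this assay.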